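Swapping 2-Hydroxyphenyl for 4-Hydroxyphenyl on a Shared Core

This account rests on a few compounds, and the source may have more. Where it says the series, first, only, none or still open, it means among the compounds named here.

In a functional assay on DU-145 cells (Homo sapiens) for cytotoxicity, read by ELISA, with a stated time of 2 days (a higher number here means a weaker inhibitor, a lower number a stronger inhibitor), compound 1 `Oc1cccc(-c2cc(-c3ccccc3)cc(-c3ccco3)n2)c1` gives 14400 nM. Compound 2 `Oc1ccccc1-c1cc(-c2ccccc2)nc(-c2ccco2)c1` gives 4900 nM, the lower of the two numbers and so the stronger result, and its gap to compound 1 is larger than the usual scatter of repeated measurements.

Compound 3 `Oc1ccc(-c2cc(-c3ccccc3)nc(-c3ccco3)c2)cc1` has not yet been measured. It has the same atoms as compound 2, joined differently: 4-hydroxyphenyl in place of 2-hydroxyphenyl on an aromatic carbon. In words, 4-hydroxyphenyl takes the place of 2-hydroxyphenyl on an aromatic carbon, opposite the ring nitrogen. Going by the values given here, no pair of measured compounds here differs in just one place, so the data offer no direct precedent for this change. The expectation rests only on the two measured values, which leaves compound 3 most likely near compound 2 and somewhat toward compound 1. The expected change is small and toward a higher number, meaning a weaker result, and it may not exceed the scatter: a 1.4-fold higher number from compound 2 to compound 3 (0.15 log units; within the scatter). For compound 3, the estimate is 7000 nM, with an expected range of 2200 nM to 20000 nM.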

Compound 3, half-maximal inhibitory concentration: 8600 nM
For compound 3 the middle estimate is 1.2-fold (0.09 log units) below the measured one; measured number inside the range.
By their numbers in this assay, from the lowest: compounds 2, 3 and 1 (each within the scatter of the next, the first and the last beyond it).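

In this assay, going by these compounds alone, 4-hydroxyphenyl in place of 2-hydroxyphenyl on the aromatic carbon opposite the ring nitrogen gives a 1.8-fold higher number from compound 2 to compound 3 (0.24 log units; within the scatter), and this is the first comparison here in which only one place differs. For these two compounds, then, where the hydroxyl group sits on this phenyl ring makes no difference that can be told apart from the ordinary spread of repeated measurements, so this assay does not separate the 2-hydroxyphenyl and 4-hydroxyphenyl groups at this position. Nothing else available bears on this result, and it comes with no explanation.

The compounds shown leave open whether the hydroxyl group matters at all at this position, a question that a comparison with an unsubstituted phenyl group, a methoxy group or an amine in its place could address. They also leave open whether a larger change at this same carbon, such as a phenyl ring carrying a carboxylic acid, would move the number by more than the scatter.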